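Swapping a Methylpyrrolyl for a Branched Alkyl Chain

The source may report more compounds than this note shows. Statements on the series, on what has been measured and on what is new or still open speak of the compounds shown alone.

Compound 1 `CCCC(CCC)Nc1ncnc2c1ncn2C1O[C@H](CO)[C@@H](O)[C@H]1O`: in an assay on cell membranes for binding affinity to adenosine receptor A1 (Cavia porcellus), read by radioligand binding (a lower number here means a stronger inhibitor, a higher number a weaker inhibitor), compound 1 gives 3.3 nM.
Compound 2 `CCCn1c(=O)c2nc(CC(C)(C)C)[nH]c2n(CCC)c1=O`: in this assay compound 2 gives 49 nM.
Compound 3 `CCCn1c(=O)c2nc(-c3cccn3C)[nH]c2n(CCC)c1=O`: in this assay compound 3 gives 140 nM.

Compound 3 stands highest of the three numbers in this assay. Its nearest neighbour is compound 2, which shares its core and differs only at one aromatic carbon; compound 1, built on a different core, lies furthest away with a much lower number. For the measured compounds named here, the one measured step within the shared core is a 2.9-fold higher number from compound 2 to compound 3 (0.46 log units; beyond the scatter), which came with 1-methyl-1H-pyrrol-2-yl in place of neopentyl on an aromatic carbon.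

Compound 4 `CCCn1c(=O)c2nc(C(C)(C)CCC)[nH]c2n(CCC)c1=O` is the next member of this series. It differs from compound 3 by 1,1-dimethylbutyl in place of 1-methyl-1H-pyrrol-2-yl on an aromatic carbon. This change bears directly on the measured step: it removes the same 1-methyl-1H-pyrrol-2-yl whose arrival raised the number, and puts back a branched alkyl group one carbon longer than the neopentyl of compound 2. The author therefore expects the number for compound 4 to fall back toward that of compound 2, an expected step of a 3.5-fold lower number from compound 3 to compound 4 (0.54 log units; beyond the scatter). The estimate for compound 4 in this assay is 40 nM, with a range from 15 nM to 120 nM.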

Compound 4, inhibition constant: 25 nM
For compound 4 the middle estimate is 1.6-fold (0.20 log units) above the measured one; low and high end bracket the measured number.
By their numbers in this assay, from the lowest: compound 1; then compounds 4 and 2 (each within the scatter of the next); then compound 3.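

With 1,1-dimethylbutyl on the aromatic carbon between two ring nitrogen atoms, the shared core comes back from the level of compound 3 in this assay, the step being a 5.6-fold lower number from compound 3 to compound 4 (0.75 log units; beyond the scatter) and running opposite to the earlier 2.9-fold higher number from compound 2 to compound 3 (0.46 log units; beyond the scatter). For the compounds shown here, two different branched alkyl groups can now be compared at this place, and they cannot be told apart, with a 2.0-fold lower number from compound 2 to compound 4 (0.29 log units; within the scatter), so among the compounds on this core the higher number belongs to compound 3, the only one carrying a ring here, and not to one particular alkyl group. Nothing available explains why the number moves with this change.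

Whether the difference follows the ring as such, its nitrogen or its methyl stays open, as the compounds shown offer no comparison with phenyl, an unmethylated pyrrol-2-yl or cyclohexyl at this place. Also open, from the compounds shown here alone, is how an unbranched chain such as n-pentyl, or an amine on this carbon, would compare with the two branched alkyl groups.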